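The source may report more compounds than this note shows. Statements on the series, on what has been measured and on what is new or still open speak of the compounds shown alone.

Three compounds that share one core differ at a single place. In a functional assay on A2780 cells (Homo sapiens) for antiproliferative activity, read by MTT assay, with a stated time of 48 h (a higher number here means a weaker inhibitor of growth, a lower number a stronger inhibitor of growth), compound 1 `COC(=O)N1N=C(c2cccc(OC)c2)CC1c1cc(OC)c(OC)c(OC)c1` gives 2780 nM, and compound 2 `CCOC(=O)N1N=C(c2cccc(OC)c2)CC1c1cc(OC)c(OC)c(OC)c1` gives 7300 nM. Compound 3 `CCCOC(=O)N1N=C(c2cccc(OC)c2)CC1c1cc(OC)c(OC)c(OC)c1` gives > 10000 nM, which is a limit of the assay and not a number. Compound 3 therefore has no exact place on the scale.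

Compound 4 `COc1cccc(C2=NN(C(=O)OCc3ccccc3)C(c3cc(OC)c(OC)c(OC)c3)C2)c1` has not yet been measured. It carries phenyl in place of ethyl on a saturated chain carbon bound to an oxygen next to a carbonyl group, so propoxycarbonyl becomes benzyloxycarbonyl: phenyl in place of ethyl on a saturated chain carbon bound to an oxygen next to a carbonyl group.

Three measured steps at this place bear on the change. Methyl in place of hydrogen gave a 2.6-fold higher number from compound 1 to compound 2 (0.42 log units; beyond the scatter), and ethyl in place of hydrogen gave an at least 3.5-fold higher number from compound 1 to compound 3 (0.55 log units; beyond the scatter). The last step, an at least 1.3-fold higher number from compound 2 to compound 3 (0.13 log units; that floor lies within the scatter), has a floor that lies within the scatter. Across these three compounds, growing the chain has only raised the number, but none of them carries a ring at this place. In this assay a weak compound 4 is therefore expected, with no clear step beyond the scatter and a real chance of another limit. The expected change is a step that the limit leaves unreadable from compound 3 to compound 4. For compound 4 the estimated value is 12000 nM, within an expected range of 4000 nM to 40000 nM.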

Compound 4, concentration for 50% growth inhibition: > 10000 nM
Compound 4: a limit, no number (the forecaster's own chance of this, stated with the estimate: 60%); the middle value is on the limit's open side.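

In this assay compound 4 gives > 10000 nM, which is a limit of the assay and not a number, so a phenyl ring on a saturated chain carbon bound to an oxygen next to a carbonyl group does not bring the series back to a measurable value. Set against the smallest group shown, phenyl in place of hydrogen gives an at least 3.5-fold higher number from compound 1 to compound 4 (0.55 log units; beyond the scatter), so the loss seen with the chains also holds for this ring, while phenyl in place of methyl gives an at least 1.3-fold higher number from compound 2 to compound 4 (0.13 log units; that floor lies within the scatter), a floor too small to separate those two compounds. Whether phenyl is better or worse than ethyl at this place cannot be read, because both compounds stop at the same limit: the limit of > 10000 nM in this assay, at which 2 of the 4 values shown sit.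

The compounds shown leave open whether a chain ending in an amine or a carboxylic acid at this place would give a readable value. They also do not show how far past the limit compound 3 and compound 4 really lie.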